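Metabolic stability notes: removing one ester from compound 1

The source may hold more compounds than are shown below. What is called first, only, known or untested is meant among the compounds shown, and "the series" means these compounds.

Measured compounds:
compound 1 `Cc1oc(=O)oc1COC(=O)C1=C(S[C@@H]2CN[C@H](C(=O)Nc3cccc(C(=O)OCc4oc(=O)oc4C)c3)C2)[C@H](C)[C@@H]2[C@@H]([C@@H](C)O)C(=O)N12`: > 95%
compound 2 `COC(=O)OCOC(=O)C1=C(S[C@@H]2CN[C@H](C(=O)Nc3cccc(C(=O)OCOC(=O)OC)c3)C2)[C@H](C)[C@@H]2[C@@H]([C@@H](C)O)C(=O)N12`: > 95%
compound 3 `CCOC(=O)C1=C(S[C@H]2C[C@@H](C(=O)Nc3cccc(C(=O)OCC)c3)N(Cc3oc(=O)oc3C)C2)[C@H](C)[C@@H]2[C@@H]([C@@H](C)O)C(=O)N12`: > 95%

In an ADME assay for metabolic stability, read by LC-MS, with a stated time of 3 h, at pH 6.5, tested at 50 uM (on this read-out lower numbers stand for a less stable compound and higher numbers for a more stable compound), compound 1 gives > 95%, which is a limit of the assay and not a number. In this assay compound 2 gives > 95%, also a limit. In this assay compound 3 gives > 95%, again a limit. For the measured compounds named here, the picture is the limit of > 95% in this assay, at which 3 of the 3 values shown sit, so compound 1 stands at that limit together with every other measured compound, and no step between measured compounds can be read off.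

Compound 4 `Cc1oc(=O)oc1COC(=O)c1cccc(NC(=O)[C@@H]2C[C@H](SC3=C(C(=O)O)N4C(=O)[C@H]([C@@H](C)O)[C@H]4[C@H]3C)CN2)c1` differs from compound 1 by a hydrogen atom in place of a group of 8 heavy atoms (5 carbon, 3 oxygen; one five-membered aromatic ring with 2 hetero atoms), on an oxygen next to a carbonyl group. With every measured value sitting at the limit, neither size nor direction of a step in this assay can be drawn from the data. Compound 4 is expected to give 90%, in the range 70% to 100%. The expected step of a number at least 5 percentage points lower from compound 1 to compound 4 (that floor lies within the scatter) is estimated as small, possibly within scatter.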

Compound 4, percent of the compound remaining: > 95%
Compound 4 gave a limit, no number (the forecaster's own chance of this, stated with the estimate: 50%); middle value at least 5 percentage points away from the limit.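

No step can be read from compound 1 to compound 4 in this assay, because both values are limits and not numbers: the limit of > 95% in this assay, at which 4 of the 4 values shown sit.

The compounds shown leave open what a hydrogen atom in place of the group of 8 heavy atoms does in this assay, since none gives a value away from that limit: the limit of > 95% in this assay, at which 4 of the 4 values shown sit.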